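This account rests on a few compounds, and the source may have more. Where it says the series, first, only, none or still open, it means among the compounds named here.

Working notes on the series. The shared core of compound 1 `COc1ccc(-c2ccc(C)n2-c2ccc(-c3nc4ccccc4s3)cc2)cc1` carries the first measured value: in a functional assay on MDA-MB-231 cells (Homo sapiens) for cytotoxicity, read by MTT assay, with a stated time of 72 h (a lower number here means a stronger inhibitor, a higher number a weaker inhibitor), compound 1 gives 14800 nM. Compound 2 `Cc1ccc(-c2ccc([N+](=O)[O-])cc2)n1-c1ccc(-c2nc3ccccc3s2)cc1` gives 12100 nM in this assay, and compound 3 `COc1cc(-c2ccc(C)n2-c2ccc(-c3nc4ccccc4s3)cc2)cc(OC)c1OC` gives 16000 nM. Compound 2 holds the lowest of the three numbers, but its distance to compound 1 and to compound 3 is within the scatter, so no order among the three is claimed.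

Among the measured compounds shown here, the one single-point step known so far is a 1.2-fold lower number from compound 1 to compound 2 (0.09 log units; within the scatter), and it is within the scatter.

Compound 4 `Cc1ccc(-c2ccc([N+](=O)[O-])cc2)n1-c1ccc(-c2nc3ccc(F)cc3s2)cc1` is not yet measured. It differs from compound 2 by fluoro in place of hydrogen on an aromatic carbon; cut one bond further out, the change reads 1,3-benzothiazol-2-yl to 6-fluoro-1,3-benzothiazol-2-yl. For the measured compounds named here, no measured step touches this ring system: the step from compound 1 to compound 2 sits on the other ring and was itself flat. There is therefore no basis for expecting a step beyond the scatter in either direction.

The estimated step is a 1.0-fold lower number from compound 2 to compound 4 (0.00 log units; within the scatter), meaning no change beyond the scatter is expected. Compound 4 is expected to give about 12000 nM in this assay, with a range from 6000 nM to 24000 nM.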

Compound 4, half-maximal inhibitory concentration: 17000 nM
Compound 4: the middle estimate sits 1.4-fold (0.15 log units) below what was measured, within the range that was stated.
By their numbers in this assay, from the lowest: compounds 2, 1, 3 and 4 (each within the scatter of the next).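

In this assay, among the compounds shown here, the step to the 6-fluoro-1,3-benzothiazol-2-yl group gives the first reading on this ring system: a 1.4-fold higher number from compound 2 to compound 4 (0.15 log units; within the scatter). Fluoro in place of hydrogen at this aromatic carbon of the fused system therefore cannot be told apart from hydrogen in this series, and the single atom added here does not separate compound 4 from compound 2. For the compounds shown here, the only other single-point step, a 1.2-fold lower number from compound 1 to compound 2 (0.09 log units; within the scatter), lies on the other ring and is also within the scatter, so neither of the two places changed has yet produced a readable difference, and no data on these compounds bear on this result.

The compounds shown leave open whether a different group at this same aromatic carbon, such as an amine, a carboxylic acid or a longer alkyl chain, would give a step beyond the scatter, since fluoro is the only replacement for hydrogen on this ring system here. They also leave open whether the flat step from fluoro holds when the nitro group of compound 4 is replaced by the methoxy group of compound 1.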